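The source may hold more compounds than are shown below. What is called first, only, known or untested is meant among the compounds shown, and "the series" means these compounds.

In an ADME assay on microsomes (Canis lupus familiaris) for metabolic stability (a higher number here means that the compound lasts longer, a lower number that the compound disappears faster), compound 1 (`O=c1[nH]nc2ccc(-c3ccc(Oc4ccc(F)cc4)cc3)cn12`) gives 4.55 h and compound 2 (`Cc1noc(Cn2nc3ccc(-c4ccc(Oc5ccc(F)cc5)cc4)cn3c2=O)n1`) gives 3.62 h. These two values lie within the scatter of each other, so no order can be read between them. Compound 3 (`O=c1n(Cc2noc(CO)n2)nc2ccc(-c3ccc(Oc4ccc(F)cc4)cc3)cn12`) is not yet measured; it carries (5-(hydroxymethyl)-1,2,4-oxadiazol-3-yl)methyl in place of hydrogen on an aromatic nitrogen of compound 1 ((5-(hydroxymethyl)-1,2,4-oxadiazol-3-yl)methyl in place of hydrogen on an aromatic nitrogen). Among the compounds with values here, only one measured step bears on this change, the replacement of that same hydrogen by (3-methyl-1,2,4-oxadiazol-5-yl)methyl, which is a 1.3-fold lower number from compound 1 to compound 2 (0.10 log units; within the scatter) and so stays small. Within the data shown here, the hydroxymethyl group itself has no measured precedent, so the range is kept wide. No change beyond the scatter is therefore expected in this assay, and the estimated step, a 1.3-fold lower number from compound 1 to compound 3 (0.13 log units; within the scatter), is expected to stay within it. For compound 3 the estimate is 3.4 h, with an expected range from 1.7 h to 6.5 h.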

Compound 3, half-life: 3.02 h
Compound 3: the middle estimate sits 1.1-fold (0.05 log units) above what was measured; low and high end bracket the measured number.
By their numbers in this assay, from the lowest: compounds 3, 2 and 1 (each within the scatter of the next).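

With compound 3, a second substituent on this aromatic nitrogen, now bearing a hydroxymethyl group, also stays within the scatter in this assay: a 1.5-fold lower number from compound 1 to compound 3 (0.18 log units; within the scatter). Exchanging one oxadiazole substituent for the other, 5-(hydroxymethyl)-1,2,4-oxadiazol-3-yl in place of 3-methyl-1,2,4-oxadiazol-5-yl, gives a 1.2-fold lower number from compound 2 to compound 3 (0.08 log units; within the scatter), so neither of the two substituents shown here separates from the other or from hydrogen in this assay. No supporting data bear on the reason for this result.

The step from compound 2 to compound 3 changes both the oxadiazole attachment and the methyl or hydroxymethyl group, and these two changes cannot be told apart here. On these data alone, it remains open whether an amine or a carboxylic acid in place of the hydroxymethyl group, or a longer chain carrying the oxadiazole, would move the half-life beyond the scatter.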